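The compounds below may be only part of what the source reports. "The series", "measured", "known", "first", "only" and "open" are said of these compounds alone.

Hemolysis read-out in an ADME assay on cells (Erythrocyte, Homo sapiens) for activation, read by hemolysis, with a stated time of 30 min, tested at 1.25 mM (a higher number here means a stronger effect of the compound at the concentration tested, a lower number a weaker effect), for the measured members of the series:

compound 1 `N=C(N)c1ccc(-c2ccc(-c3cc(Cl)cc(Cl)c3)s2)s1`: "non-toxic" (no number reported)
compound 2 `COc1ccc(-c2ccc(-c3ccc(C(=N)N)s3)s2)cc1`: 17.3%
compound 3 `N=C(N)c1ccc(-c2ccc(-c3ccc(F)cc3)o2)o1`: "non-toxic" (no number reported)

Compound 2 is the only entry in this assay with a number; compounds 1 and 3 are recorded as non-toxic without a value, so compound 2 cannot be ordered against them. Compound 4 `N=C(N)c1ccc(-c2ccc(-c3ccc(F)cc3)s2)s1` has not yet been tested in this assay. It differs from compound 2 by fluoro in place of methoxy on an aromatic carbon. Among the measured compounds shown here, no step between two measured compounds is available in this assay, so the size of the change has to be judged from the set alone. Compound 3 also carries fluoro and gives "non-toxic" (no number reported), which points toward a modest downward step, about at the edge of the scatter. Compound 4 is therefore estimated at 8%, range 0% to 20%. That estimate corresponds to an expected step of a number 9.3 percentage points lower from compound 2 to compound 4 (within the scatter).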

Compound 4, a percentage reported as activity, at one concentration (the size of the read-out at that concentration, not a potency): "non-toxic" (no number reported)
The entry for compound 4 holds no number, and the estimate cannot be compared.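

Among the compounds shown here, compound 4 is recorded as "non-toxic" (no number reported) in this assay, so no step from compound 2 can be read. The compounds shown leave open how far fluoro in place of methoxy shifts hemolysis. No evidence bears on this result.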